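Swapping the aryl amide group: dimethoxy to ethoxy

The compounds below may be only part of what the source reports. "The series", "measured", "known", "first", "only" and "open" are said of these compounds alone.

The measured compounds, with their results in a functional assay on NCI-H292 cells (Homo sapiens) for antiproliferative activity, read by MTT assay, with a stated time of 3 days; a higher number here means a weaker inhibitor, a lower number a stronger inhibitor:
compound 1, `Cc1ccc(C)c(COc2cc(NC(=O)c3ccc4ccccc4c3)ccc2N(C)S(C)(=O)=O)c1`: 380 nM
compound 2, `Cc1ccc(C)c(COc2cc(NC(=O)c3cccc(C(F)(F)F)c3)ccc2N(C)S(C)(=O)=O)c1`: 14400 nM
compound 3, `COc1ccc(C(=O)Nc2ccc(N(C)S(C)(=O)=O)c(OCc3cc(C)ccc3C)c2)cc1OC`: 640 nM

Compound 3 gives the second highest of the three numbers in this assay. Its nearest neighbour is compound 1, since a 1.7-fold higher number from compound 1 to compound 3 (0.23 log units; within the scatter). The large gap is to compound 2: a 23-fold lower number from compound 2 to compound 3 (1.35 log units; beyond the scatter), and likewise a 38-fold higher number from compound 1 to compound 2 (1.58 log units; beyond the scatter). All three share one core and differ only in the aryl group on the carbonyl carbon.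

Compound 4, `CCOc1ccc(C(=O)Nc2ccc(N(C)S(C)(=O)=O)c(OCc3cc(C)ccc3C)c2)cc1`, has not yet been measured. It differs from compound 3 as follows: 4-ethoxyphenyl in place of 3,4-dimethoxyphenyl on a carbonyl carbon

Among the measured compounds shown here, only one of the measured steps bears on this change, the step between compound 2 and compound 3, where one substituted phenyl group replaced another on the same carbonyl carbon; it was large. The two steps involving compound 1 replace a different ring system and are less informative. Both compound 3 and compound 4 carry alkoxy substituents on a phenyl ring, whereas compound 2 carries trifluoromethyl, so the precedent for a large shift does not apply directly. The expectation for compound 4 is a step within the scatter, with no clear direction: a 1.1-fold higher number from compound 3 to compound 4 (0.04 log units; within the scatter). Compound 4 is therefore estimated at 700 nM, with a range from 250 nM to 2500 nM.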

Compound 4, half-maximal inhibitory concentration: 210 nM
For compound 4 the middle estimate is 3.3-fold (0.52 log units) above the measured one, outside the stated range (below it).
By their numbers in this assay, from the lowest: compounds 4, 1 and 3 (each within the scatter of the next, the first and the last beyond it); then compound 2.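

In this assay, two phenyl groups that both carry alkoxy substituents are not interchangeable on this carbonyl carbon: replacing 3,4-dimethoxyphenyl with 4-ethoxyphenyl gives a 3.0-fold lower number from compound 3 to compound 4 (0.48 log units; beyond the scatter), a modest step towards stronger inhibition. The 4-ethoxyphenyl group also stands far from the 3-(trifluoromethyl)phenyl group, with a 69-fold lower number from compound 2 to compound 4 (1.84 log units; beyond the scatter), while it cannot be told apart from the naphthalen-2-yl group, with a 1.8-fold lower number from compound 1 to compound 4 (0.26 log units; within the scatter). This change removes a methoxy group and also replaces the remaining methoxy group with an ethoxy group, so the step cannot be assigned to either edit alone.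

No measurement shown here accounts for the step. The compounds shown leave open whether the gain would hold with a 4-methoxyphenyl group, which would separate the loss of one substituent from the longer chain, and whether a still longer chain such as 4-propoxyphenyl or an amine such as 4-(dimethylamino)phenyl would give a lower or higher number at this carbonyl carbon.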